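Compound 3: one methyl fewer on the lactam

A few compounds are considered here, and "the series" means these few. Any claim that something is new, unique, unknown or untested is made for them only; others in the source may bear on it.

Measured values in a physicochemical assay for lipophilicity, using the shake flask method, in phosphate buffer, measured as octanol-water partition, with a stated time of 30 min, at pH 7.4 (a higher number here means a more lipophilic compound, a lower number a more polar compound), are
- compound 1 `Cc1nc(CO)ccc1-c1cnc(NCc2c(F)ccc3c2CCO3)c2cn[nH]c(=O)c12` gives 2.4
- compound 2 `CC1(C)CC(=O)N(c2cnc(NCc3c(F)ccc4c3CCO4)n3cnnc23)C1` gives 2

Compound 2 at 2 is the lower of the two numbers, and compound 1 at 2.4 stands higher, beyond the scatter. Compound 3 `C[C@H]1CC(=O)N(c2cnc(NCc3c(F)ccc4c3CCO4)n3cnnc23)C1` has not yet been measured. It carries 4-methyl-2-oxopyrrolidin-1-yl in place of 4,4-dimethyl-2-oxopyrrolidin-1-yl on an aromatic carbon, and the entering group has 1 defined stereocentre. Among the measured compounds shown here, no two measured compounds differ in one place, so no measured step guides this change. The expected shift in this assay is a modest fall, just beyond the scatter, estimated as a number 0.40 log units lower from compound 2 to compound 3 (beyond the scatter) and resting on the structural change alone. For compound 3 the estimated value is 1.6 with an expected range from 1.2 to 2 in this series.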

Compound 3, distribution coefficient: 1.8
Estimate against measurement, compound 3: 0.20 log units below; the measured number falls inside the stated range.
By their numbers in this assay, from the lowest: compounds 3 and 2 (each within the scatter of the next); then compound 1.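

Among the compounds shown here, this is the first step that changes a single place: in this assay, 4-methyl-2-oxopyrrolidin-1-yl in place of 4,4-dimethyl-2-oxopyrrolidin-1-yl on an aromatic carbon gives a number 0.20 log units lower from compound 2 to compound 3 (within the scatter) and leaves the two compounds not separable on this read-out. At this position, the change of one methyl on the lactam, together with the defined stereocentre that enters, therefore does not take the distribution coefficient beyond the usual scatter. No measurement at hand accounts for this step.

Still open, as far as these compounds go, is whether a larger change here would separate from compound 2, such as an ethyl chain on the lactam or an amine in place of the methyl. Also open, from the compounds shown here alone, is how the unsubstituted 2-oxopyrrolidin-1-yl group and the opposite stereoisomer of compound 3 would read in this assay.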